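A few compounds are considered here, and "the series" means these few. Any claim that something is new, unique, unknown or untested is made for them only; others in the source may bear on it.

Measured compounds in a functional assay on HCT-116 cells (Homo sapiens) for inhibition, read by CCK-8 assay, with a stated time of 72 h, tested at 2 uM; a lower number here means less inhibition of growth, a higher number more inhibition of growth at the concentration tested:

compound 1, `COc1ccc(SCc2ccc(/C=C/C(=O)Nc3ccccc3N)cc2)cc1OC`, 12.9%
compound 2, `Nc1ccccc1NC(=O)c1ccc(CSc2nccc(C(F)(F)F)n2)cc1`, 82.7%
compound 3, `Nc1ccccc1NC(=O)c1ccc(CSc2cccc(F)c2)cc1`, 5.5%

Compound 1 stands second highest of the three numbers. Its nearest neighbour is compound 3, whose value lies lower by an amount that is within the usual scatter, so the two are not told apart by these data. Compound 2 stands far above compound 1, by a gap well beyond the scatter, and it is the only one of the three with a heteroaromatic ring on the sulfur; compound 1 and compound 3 both carry a carbon-only aromatic ring there and both give low numbers.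

Compound 4, `CC(C)(C)c1ccc(SCc2ccc(/C=C/C(=O)Nc3ccccc3N)cc2)cc1`, is not yet measured. It differs from compound 1 in one place: 4-(tert-butyl)phenyl in place of 3,4-dimethoxyphenyl on a sulfur. Two hydrogen-bond acceptors leave and none enter; the count of heavy atoms stays the same.

Within the data shown here, no step between measured compounds reports what such a change does in this assay. The two carbon-only aromatic rings on sulfur among the measured set, in compound 1 and compound 3, both sit low, and nothing here points to a large move in either direction. The author expects the step from compound 1 to compound 4 to be small, a number 2.1 percentage points higher from compound 1 to compound 4 (within the scatter), not clearly beyond the scatter. Compound 4 is estimated at 15%, within a range from 0% to 40%.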

Compound 4, percent growth inhibition at one concentration: 6.66%
The estimate for compound 4 lay 8.3 percentage points above the measured number; the measured number falls inside the stated range.
By their numbers in this assay, from the lowest: compounds 3, 4 and 1 (each within the scatter of the next); then compound 2.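

In this assay, 4-(tert-butyl)phenyl in place of 3,4-dimethoxyphenyl on a sulfur gives a number 6.2 percentage points lower from compound 1 to compound 4 (within the scatter), the first step read at this position, and it does not tell the two groups apart. The change removes the hydrogen-bond acceptors of the leaving group and leaves an aromatic ring of carbon only with the same heavy-atom count, so on the core of compound 1 the read-out at this single concentration does not depend detectably on whether those acceptors are present. Nothing in hand bears on what lies behind this result.

The compounds shown leave open whether any group on the sulfur can move this core clear of the scatter, for instance a phenyl ring carrying a carboxylic acid or an amine, or a heteroaromatic ring in place of the phenyl ring. They also leave open whether compound 1 and compound 4 would still be indistinguishable at another concentration or in another cell line, as this comparison rests on one step in one assay.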